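Swapping the pyrimidine of compound 1 for a dimethylisoxazole

The source may report more compounds than this note shows. Statements on the series, on what has been measured and on what is new or still open speak of the compounds shown alone.

Compound 1 `Cn1c(-c2ccc(-c3cncnc3)cc2)nnc1C1(c2ccc(Cl)cc2)CCC1` has the lowest number of the three measured compounds in a functional assay on the whole organism (strain ICR) for inhibition, with Mus musculus as the target, read by scintillation counting, with a stated time of 4 h, at a dose of 10 mg/kg by the oral route (on this read-out lower numbers stand for less inhibition and higher numbers for more inhibition at the one dose given (going by the name of the read-out)), where compound 1 gives 46%. Compound 2 `Cn1c(-c2ccc(C(=O)O)cc2Cl)nnc1C1(c2ccc(Cl)cc2)CCC1` gives 90% in this assay, and compound 3 `Cn1c(-c2ccc(-c3cccnc3)cc2Cl)nnc1C1(c2ccc(Cl)cc2)CCC1` gives 100%. The gaps from compound 1 to each of these lie beyond the scatter, so compound 1 stands clearly at the bottom. Among the measured compounds shown here, the one step between neighbours, a number 10 percentage points higher from compound 2 to compound 3 (within the scatter), sits within the scatter and therefore shows no real change.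

Compound 4 `Cc1noc(C)c1-c1ccc(-c2nnc(C3(c4ccc(Cl)cc4)CCC3)n2C)cc1` differs from compound 1 in a single place: 3,5-dimethyl-1,2-oxazol-4-yl in place of pyrimidin-5-yl on an aromatic carbon. The change sits on an aromatic carbon of a six-membered aromatic ring of carbon only, para to a large group. For the measured compounds named here, no measured step concerns this ring of compound 1, and the step from compound 2 to compound 3 exchanges a carboxy for a pyridin-3-yl on a different ring, so it bears on the present swap only loosely. The account therefore rests on the spread of the three numbers. Compound 4 is expected to move by about a number 9 percentage points higher from compound 1 to compound 4 (within the scatter), no more than the scatter. Compound 4 is estimated at 55%, in a range from 25% to 85%.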

Compound 4, a percentage reported as inhibition, in the whole organism at one dose (the size of the read-out at that dose, not a potency): 63%
Beside the measured number, compound 4's estimate is 8 percentage points below it; low and high end bracket the measured number.
By their numbers in this assay, from the lowest: compound 1; then compound 4; then compounds 2 and 3 (each within the scatter of the next).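

Among the compounds shown here, at the aromatic carbon para to a large group, putting 3,5-dimethyl-1,2-oxazol-4-yl in place of pyrimidin-5-yl gives, in this assay, a number 17 percentage points higher from compound 1 to compound 4 (beyond the scatter), the first measured step at this position of the shared core. It shows that this read-out at the one oral dose responds to the group held here, even though a six-membered aromatic ring with 2 hetero atoms gives way to a five-membered aromatic ring with 2 hetero atoms and the counts of hydrogen-bond donors and acceptors stay the same on both sides. Nothing measured here accounts for the size or direction of this step.

Going by these compounds, as a single pair, compound 1 and compound 4 do not separate the change in ring size from the presence of the two methyl groups on the entering ring, so the share of each in the step remains open. On these data alone, how an amine or a morpholine ring would read at this same position also remains open, as does whether the step would hold in a core with a different substitution pattern.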